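Methyl for Chloro on a Phosphoserine Lipid Analogue

This account rests on a few compounds, and the source may have more. Where it says the series, first, only, none or still open, it means among the compounds named here.

Measured so far:
- compound 1 `N[C@@H](COP(=O)(O)O[C@@H]1CCCO[C@@H]1COC(=O)CCc1ccccc1OCc1cccc(Oc2ccc(Cl)cc2)c1)C(=O)O` gives "not active" (no number reported)
- compound 2 `N[C@@H](COP(=O)(O)OC[C@H]1OCCC[C@H]1OC(=O)CCc1ccc(OCc2cccc(Oc3ccccc3)c2)cc1)C(=O)O` gives "not active" (no number reported)
- compound 3 `CCCCCCCCCCCOc1ccccc1CCC(=O)OC[C@H]1OCC=C[C@@H]1OP(=O)(O)OC[C@H](N)C(=O)O` gives 7.6%

All three were tested in an assay on HEK293-A cells for agonist activity at putative P2Y purinoceptor 10 (Mus musculus), with a stated time of 1.5 h; a lower number here means a smaller maximal response, a higher number a larger maximal response. Compound 1 stands with no single number: in this assay it was reported as "not active" (no number reported), and compound 2 shares that outcome, also without a number. Only compound 3 carries a measured value, 7.6%, which is a small maximal response on this scale. Within the data shown here, with two of the three results given as words rather than numbers, no steps between measured compounds can be computed, and nothing can be said about how a change at one place moves the read-out.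

Compound 4 `Cc1ccc(Oc2cccc(COc3ccccc3CCC(=O)OC[C@H]3OCCC[C@H]3OP(=O)(O)OC[C@H](N)C(=O)O)c2)cc1` is the compound still to be tested. It differs from compound 1 in a single place: methyl in place of chloro on an aromatic carbon. The rest of the shared core is unchanged.

Among the measured compounds shown here, with compound 1 reported as "not active" (no number reported) and no step available, the expectation for this assay is no step beyond the usual scatter in either direction, and a fair chance that compound 4 is again reported only in words. Compound 4 is estimated at 5%, with a range from 0% to 15%.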

Compound 4, largest response reached (Emax), in percent of the reference or control that the assay uses: "not active" (no number reported)
Compound 4 has no reported number here; there is nothing to compare the estimate with.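

Compound 1 and compound 4 are both reported in this assay only in words, without a number, and no step can be read between them. No measured information bears on this result. The compounds shown leave open whether changing 4-chlorophenyl to 4-methylphenyl alters the maximal response at all.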